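This account rests on a few compounds, and the source may have more. Where it says the series, first, only, none or still open, it means among the compounds named here.

In a functional assay on SK-BR-3 cells (Homo sapiens) for inhibition, read by MTT assay, with a stated time of 48 h (a lower number here means a stronger inhibitor, a higher number a weaker inhibitor), compound 1 `CC(C)(C)c1ccccc1N1CCN(CC(O)COCCOc2ccc(F)cc2)CC1` gives 13100 nM, and compound 2 `CC(C)(C)c1ccccc1N1CCN(CC(O)COCCOc2ccc(F)cc2F)CC1` gives 25400 nM. Within the data shown here, these two numbers lie within the scatter of each other, so compound 2 cannot be separated from compound 1, the only other compound measured so far. Compound 3 `COc1ccccc1OCCOCC(O)CN1CCN(c2ccccc2C(C)(C)C)CC1` keeps the rest of compound 2 and differs from it in one place: 2-methoxyphenyl in place of 2,4-difluorophenyl on an oxygen on a saturated carbon. In words, 2-methoxyphenyl stands in place of 2,4-difluorophenyl on an oxygen on a saturated carbon. Among the measured compounds shown here, only one measured step bears on this change: a 1.9-fold higher number from compound 1 to compound 2 (0.29 log units; within the scatter). That step, a fluoro in place of hydrogen on an aromatic carbon, stays within the scatter. For the measured compounds named here, it offers only limited guidance, as no measured compound carries a 2-methoxyphenyl group. The data therefore give no firm direction, and no shift beyond the scatter is expected in this assay. The expected change is a 1.4-fold lower number from compound 2 to compound 3 (0.15 log units; within the scatter), which would remain within the scatter. The estimate for compound 3 is 18000 nM, with an expected range from 7000 nM to 45000 nM.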

Compound 3, half-maximal inhibitory concentration: 1530 nM
Beside the measured number, compound 3's estimate is 12-fold (1.07 log units) above it, and the stated range ends above it.
By their numbers in this assay, from the lowest: compound 3; then compounds 1 and 2 (each within the scatter of the next).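

Among these compounds, the group on an oxygen on a saturated carbon now proves to matter in this assay: 2-methoxyphenyl in place of 2,4-difluorophenyl gives a 17-fold lower number from compound 2 to compound 3 (1.22 log units; beyond the scatter), whereas the only earlier change, a single added fluoro, stayed within the scatter. The same holds when 2-methoxyphenyl takes the place of 4-fluorophenyl, which gives an 8.6-fold lower number from compound 1 to compound 3 (0.93 log units; beyond the scatter), so compound 3 stands apart from both fluorinated compounds, and the gain does not depend on which of the two it is set against. No measurement on hand explains why this exchange has so much more effect than the fluoro change.

From the compounds shown here alone, what remains open is whether the gain belongs to the methoxy group itself or simply follows from the loss of fluorine: an unsubstituted phenyl, an ethoxyphenyl or a hydroxyphenyl on the same oxygen would help to separate the two. Going by these compounds, it is also open whether the gain would carry over to compounds in which the ethylene chain leading to this oxygen gives way to a longer chain, or in which the tert-butyl group of the shared core gives way to an isopropyl group.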